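The source may hold more compounds than are shown below. What is called first, only, known or untested is meant among the compounds shown, and "the series" means these compounds.

Measured compounds:
compound 1, `CCN1C(=O)S/C(=C\C2=Cc3ccccc3OC2)C1=O`
compound 2, `O=C(O)CN1C(=O)/C(=C/C2=Cc3ccccc3OC2)SC1=S`
compound 3, `CCN1C(=O)S/C(=C\C2=Cc3cccc(OC)c3OC2)C1=O`

In a functional assay on MCF7 cells (Homo sapiens) for antiproliferative activity, read by MTT assay, with a stated time of 72 h (a higher number here means a weaker inhibitor, a lower number a stronger inhibitor), compound 1 gives > 200000 nM, which is a limit of the assay and not a number (the limit of > 200000 nM in this assay, at which 1 of the 3 values shown sits). In this assay compound 2 gives > 100000 nM, again a limit of the assay rather than a number (the limit of > 100000 nM in this assay, at which 1 of the 3 values shown sits). In this assay compound 3 gives 89100 nM.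

Compound 3 differs from compound 1 by methoxy in place of hydrogen on an aromatic carbon. Going by the values given here, the step of an at least 2.2-fold lower number from compound 1 to compound 3 (0.35 log units; beyond the scatter) is the only measured step. The difference between the core of compound 1 and the core of compound 2 is not broken down here.

Compound 4, `COc1cccc2c1OCC(/C=C1\SC(=S)N(CC(=O)O)C1=O)=C2`, is not yet measured. It differs from compound 2 by methoxy in place of hydrogen on an aromatic carbon, the same kind of change that is seen from compound 1 to compound 3. Because the earlier step of an at least 2.2-fold lower number from compound 1 to compound 3 (0.35 log units; beyond the scatter) moved the number down only modestly and compound 2 sits at a limit, the expectation for compound 4 in this assay is a step of about an at least 1.1-fold lower number from compound 2 to compound 4 (0.04 log units; that floor lies within the scatter), with a real chance that only a limit is returned. The estimate for compound 4 is 90000 nM, expected to lie between 40000 nM and 200000 nM.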

Compound 4, half-maximal inhibitory concentration: > 200000 nM
Compound 4 ended at the assay's limit; the forecaster's own chance of this, stated with the estimate: 50%; middle value at least 2.2-fold (0.34 log units) from the limit.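

In this assay, compound 2 and compound 4 both stand at limits of the assay and not at numbers, and the step between them, methoxy in place of hydrogen on an aromatic carbon, cannot be read. The compounds shown leave open whether this change moves the number at all on the core of compound 2, as it does on the core of compound 1.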